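A few compounds are considered here, and "the series" means these few. Any claim that something is new, unique, unknown or untested is made for them only; others in the source may bear on it.

Of the compounds shown here, three have been measured in an assay on cells for inhibition of HSP60/HSP10 (Homo sapiens), with a stated time of 60 min; a lower number here means a stronger inhibitor, a higher number a weaker inhibitor. Compound 1 `O=S(=O)(Nc1ccc(-c2nc3ccccc3o2)cc1)c1ccccc1O` gives only a limit of the assay, > 100000 nM. Compound 2 `O=S(=O)(Nc1ccc(-c2nc3cc(NS(=O)(=O)c4ccccc4O)ccc3o2)cc1)c1ccccc1O` gives 18000 nM. Compound 3 `O=S(=O)(Nc1ccc(-c2nc3cc(NS(=O)(=O)c4cccc(O)c4)ccc3o2)cc1)c1cccc(O)c1` gives 17000 nM.

Compound 1 thus sits at the limit of what this assay reports (the limit of > 100000 nM in this assay, at which 1 of the 3 values shown sits), so its standing is known only as a bound. Among the compounds with values here, the one computed step, an at least 5.5-fold lower number from compound 1 to compound 2 (0.74 log units; beyond the scatter), adds a second sulfonamide group to the shared core and does not touch the sulfonyl end. Compound 4 `O=S(=O)(Nc1ccc(-c2nc3ccccc3o2)cc1)c1ccc(Cl)c(Cl)c1` differs from compound 1 by 3,4-dichlorophenyl in place of 2-hydroxyphenyl on a sulfonyl sulfur. No measured step bears on this change, so no direction beyond the scatter can be expected from the data shown. Compound 4 is therefore estimated at 100000 nM, with a range from 30000 nM to 300000 nM. The expected step of a number no higher from compound 1 to compound 4 (the limit leaves the size open) stays within the scatter.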

Compound 4, half-maximal inhibitory concentration: 25000 nM
Beside the measured number, compound 4's estimate is 4.0-fold (0.60 log units) above it; measured number below the stated range.
By their numbers in this assay, from the lowest: compounds 3, 2 and 4 (each within the scatter of the next). At a limit, above all of these: compound 1.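

The step at the sulfonyl sulfur, an at least 4.0-fold lower number from compound 1 to compound 4 (0.60 log units; beyond the scatter), shows that in this assay the number moves beyond the scatter with a change at the sulfonyl end alone, without a second sulfonamide group on the shared core. The size of this step stays unknown because compound 1 is known only as a bound: the limit of > 100000 nM in this assay, at which 1 of the 4 values shown sits.

On these data alone, it remains open whether the two chlorines or the loss of the hydroxyl carries the step, and how a phenyl bearing a single chlorine, a methoxy group or an amine would read at this place. Also open, as far as these compounds go, is whether 3,4-dichlorophenyl and the added sulfonamide group would add up in one compound.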